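The compounds below may be only part of what the source reports. "The series", "measured", "known", "first", "only" and "open" are said of these compounds alone.

- compound 1 `O=C(O)CCCCC(CCSC(=O)c1ccccc1)SC(=O)c1ccccc1`: 0.29%
- compound 2 `CC(=O)SCCC(CCCCC(=O)Nc1ccc(Cl)cc1)SC(C)=O`: 0.35%

In a functional assay on HO8910 cells (Homo sapiens) for inhibition, read by MTT assay, with a stated time of 24 h, tested at 1 ug/mL (on this read-out higher numbers stand for more inhibition of growth at the one concentration tested and lower numbers for less inhibition of growth), compound 1 gives 0.29% and sits within the scatter of compound 2 at 0.35%, so the two cannot be told apart. Compound 3 `O=C(CCCCC(CCSC(=O)c1ccccc1)SC(=O)c1ccccc1)Nc1ccccc1` keeps the core of compound 1 and has anilino in place of hydroxy on a carbonyl carbon. Among the compounds with values here, no measured pair shows this change on its own. With so little to go on, the expected size of a number 0.1 percentage points higher from compound 1 to compound 3 (within the scatter) in this assay stays within the scatter, with no direction expected. The estimated value for compound 3 is 0.35%, with an expected range of 0.1% to 5%.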

Compound 3, percent growth inhibition at one concentration: 3.79%
Estimate against measurement, compound 3: 3.4 percentage points below, within the range that was stated.
By their numbers in this assay, from the lowest: compounds 1, 2 and 3 (each within the scatter of the next).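

In this assay there is a number 3.5 percentage points higher from compound 1 to compound 3 (within the scatter) when anilino replaces hydroxy on a carbonyl carbon. Within the data shown here, this is the first direct view of this position: a six-membered aromatic ring can enter there without moving the number beyond the usual scatter, so these two compounds cannot be told apart. Nothing available explains this result.

The compounds shown leave open whether methylamino or benzylamino on this carbonyl carbon would move the number beyond the scatter. As far as these compounds go, what methoxy in place of hydroxy would do also remains open.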